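This account rests on a few compounds, and the source may have more. Where it says the series, first, only, none or still open, it means among the compounds named here.

Working notes on the series. In a functional assay on A-375 cells (Homo sapiens) for antiproliferative activity, read by MTT assay, with a stated time of 24 h (on this read-out lower numbers stand for stronger inhibition and higher numbers for weaker inhibition), compound 1 `C=CCOc1ccc2c(=O)c(-c3cc(OC)c(OC)cc3OC)coc2c1` gives 4750 nM and compound 2 `COc1cc(OC)c(-c2coc3cc(OCc4ccccc4F)ccc3c2=O)cc1OC` gives 2100 nM. Among the compounds with values here, compound 2 therefore holds the lower of the two numbers so far, and the gap to compound 1 lies beyond the usual scatter.

The next compound is compound 3 `COc1cc(OC)c(-c2coc3cc(OCc4ccccc4C(F)(F)F)ccc3c2=O)cc1OC`, which keeps the shared core and differs from compound 2 at one place: trifluoromethyl in place of fluoro on an aromatic carbon. This places trifluoromethyl in place of fluoro on an aromatic carbon, ortho to a large group, turning 2-fluorobenzyl into 2-(trifluoromethyl)benzyl.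

Within the data shown here, only one measured step bears on this, and only indirectly: a 2.3-fold lower number from compound 1 to compound 2 (0.35 log units; beyond the scatter). That step replaced vinyl with 2-fluorophenyl, a larger change than the one at hand, and it was modest. Among the measured compounds shown here, no measured pair yet varies a group on this aromatic ring, so the data give no direction for the new change. A step no larger than that one is expected, most likely within the scatter.

The step expected is a 1.1-fold higher number from compound 2 to compound 3 (0.06 log units; within the scatter). For compound 3 the estimated value in this assay is 2400 nM, with an expected range of 1000 nM to 5500 nM.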

Compound 3, half-maximal inhibitory concentration: > 10000 nM
Compound 3 was reported as a limit; the forecaster's own chance of this, stated with the estimate: 3%; middle value at least 4.1-fold (0.61 log units) from the limit.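

Within the data shown here, the change from 2-fluorobenzyl to 2-(trifluoromethyl)benzyl is the first variation on this aromatic ring, and in this assay it gives an at least 4.7-fold higher number from compound 2 to compound 3 (0.67 log units; beyond the scatter), so the read-out does respond to the group at this place, ortho to a large group. The value of compound 3 is a limit of the assay and not a number: the limit of > 10000 nM in this assay, at which 1 of the 3 values shown sits. The 2-fluorophenyl group brought a 2.3-fold lower number from compound 1 to compound 2 (0.35 log units; beyond the scatter), whereas the 2-(trifluoromethyl)phenyl group in the same place brings an at least 2.1-fold higher number from compound 1 to compound 3 (0.32 log units; beyond the scatter), so replacing vinyl with a substituted phenyl does not shift the read-out in one fixed direction, and the group on that phenyl ring decides the sign of the step.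

From the compounds shown here alone, the true size of both new steps stays open, since each rests on a limit, and a single pair of groups cannot show whether the sharp rise belongs to trifluoromethyl alone. Chloro, methyl or methoxy at this place would show whether the read-out stays near that of fluoro or moves towards that of trifluoromethyl, and trifluoromethyl elsewhere on the ring would show whether the place matters as much as the group.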